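The compounds below may be only part of what the source reports. "The series", "measured", "known", "first", "only" and "open" are said of these compounds alone.

Compound 1 `FC(F)(F)c1c(CN2CCC(c3ccccc3)CC2)ccn2c(CC3CC3)nnc12`: 261%
Compound 2 `CC1(c2ccccc2)CCCN(Cc2ccn3c(CC4CC4)nnc3c2C(F)(F)F)C1`: 278%
Compound 3 `FC(F)(F)c1c(CN2CCC(c3ccccc3Cl)CC2)ccn2c(CC3CC3)nnc12`: 328%

In an assay on CHO cells for positive allosteric modulation of metabotropic glutamate receptor 2 (Homo sapiens), read by scintillation counting, with a stated time of 30 min (a lower number here means a smaller maximal response, a higher number a larger maximal response), compound 3 stands highest of the three numbers; compound 2 lies nearer to it and compound 1 furthest, both gaps beyond the scatter. Compound 4 `Fc1ccc(C2CCN(Cc3ccn4c(CC5CC5)nnc4c3C(F)(F)F)CC2)c(F)c1` differs from compound 3 in one place: 2,4-difluorophenyl in place of 2-chlorophenyl on a saturated ring carbon. Among the measured compounds shown here, the one measured step that bears on this is a number 67 percentage points higher from compound 1 to compound 3 (beyond the scatter), where a chloro on the aromatic carbon raised the response. For the measured compounds named here, compound 4 keeps a halogen on that ring but exchanges chlorine for two fluorines, a change for which no measured pair exists, so the direction is uncertain. The step of a number 28 percentage points lower from compound 3 to compound 4 (beyond the scatter) is therefore expected to be small to moderate. Compound 4 is estimated at 300%, within 245% to 355%.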

Compound 4, largest response reached (Emax), in percent of the reference or control that the assay uses: 255%
Compound 4: middle estimate off by 45 percentage points, on the high side; measured number inside the range.
By their numbers in this assay, from the lowest: compounds 4 and 1 (each within the scatter of the next); then compound 2; then compound 3.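

In this assay, 2,4-difluorophenyl in place of 2-chlorophenyl on the saturated ring carbon gives a number 73 percentage points lower from compound 3 to compound 4 (beyond the scatter), and in place of phenyl it gives a number 6 percentage points lower from compound 1 to compound 4 (within the scatter). The rise seen with chloro therefore does not extend to every halogenated phenyl group at this position. Of the two halogenated groups shown, only 2-chlorophenyl stands clear of plain phenyl.

Going by these compounds, whether a bromo, a methoxy or a nitrile in place of the chloro of compound 3 would keep its response remains open. The data shown offer no measured explanation for the gap between the chloro and difluoro groups.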